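The source may hold more compounds than are shown below. What is called first, only, known or untested is meant among the compounds shown, and "the series" means these compounds.

Measured so far, in a functional assay on Umbilical vein for antagonist activity at B1 bradykinin receptor (Homo sapiens), using Schild analysis, with a stated time of 30 min; on this read-out lower numbers stand for lower potency and higher numbers for higher potency (the scale is a negative logarithm):

compound 1, `CN(Cc1ccc(C2=NCCN2)cc1)C(=O)COCCN(C)S(=O)(=O)c1c(Cl)cccc1Cl`, gives 8.5
compound 2, `Cc1c(Cl)ccc(S(=O)(=O)N(C)CC(=O)NCC(=O)N(C)Cc2ccc(C3=NCCN3)cc2)c1Cl`, gives 7.2
compound 3, `COc1cc(C)c(S(=O)(=O)N(C)CCOCC(=O)N2CCN(CC3CCN(C)CC3)CC2)c(C)c1`, gives 8.6

Compound 1 holds the second highest of the three numbers. Its nearest neighbour is compound 3, whose number lies within the usual scatter of that of compound 1, so the two cannot be ordered on this read-out. Compound 2 stands well apart, its number lying below that of compound 1 by more than the scatter.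

Compound 4, `CN(Cc1ccc(C2=NCCN2)cc1)C(=O)COCCN(C)S(=O)(=O)c1ccccc1C(F)(F)F`, differs from compound 1 in one place: 2-(trifluoromethyl)phenyl in place of 2,6-dichlorophenyl on a sulfonyl sulfur. The shared core, the sulfonamide nitrogen and the rest of the chain are unchanged; only the aryl group on the sulfonyl sulfur is exchanged.

Going by the values given here, no pair among the measured compounds carries this exchange, so the size of the step is not known from the data. A modest loss is expected rather than a gain, estimated as a number 0.50 log units lower from compound 1 to compound 4 (beyond the scatter) in this assay, possibly within the scatter. Compound 4 is therefore expected to give about 8, in the range 7.3 to 8.6.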

Compound 4, negative logarithm of the antagonist equilibrium constant: 9.2
For compound 4 the middle estimate is 1.20 log units below the measured one, outside the stated range (above it).
By their numbers in this assay, from the lowest: compound 2; then compounds 1 and 3 (each within the scatter of the next); then compound 4.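

At the aryl group on a sulfonyl sulfur, the exchange of 2,6-dichlorophenyl for 2-(trifluoromethyl)phenyl in this assay gives a number 0.70 log units higher from compound 1 to compound 4 (beyond the scatter). The 2,6-dichlorophenyl group of compound 1 is therefore not required for high potency in this series, and this place on the sulfonyl sulfur still has room for a gain with the rest of the molecule unchanged. Nothing among the data shown bears on the reason for this gain.

Open, from the compounds shown here alone, is which part of the exchange carries the step: a plain phenyl or a 2-chlorophenyl on the sulfonyl sulfur would separate the loss of the chlorines from the arrival of the trifluoromethyl. Going by these compounds alone, also open is whether the same gain appears with a different chain on the sulfonamide nitrogen, such as the one in compound 2.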